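Working notes: replacing the chain on compound 2

A few compounds are considered here, and "the series" means these few. Any claim that something is new, unique, unknown or untested is made for them only; others in the source may bear on it.

In a functional assay on P388 cells (Mus musculus) for cytotoxicity (on this read-out lower numbers stand for stronger inhibition and higher numbers for weaker inhibition), the measured compounds give these values
- compound 1 `COc1ccc2cc1Oc1ccc(cc1)C[C@H]1C(=O)N(C)[C@@H](C2)C(=O)N[C@H](C)C(=O)N[C@@H](C)C(=O)N(C)[C@@H](Cc2ccccc2)C(=O)N[C@@H](C)C(=O)N1C` gives 295 nM
- compound 2 `CCCCCN1C(=O)[C@@H](C)NC(=O)[C@@H]2Cc3ccc(OC)c(c3)Oc3ccc(cc3)C[C@@H](C(=O)N2C)N(C)C(=O)[C@H](C)NC(=O)[C@H](Cc2ccc(OC)cc2)N(C)C(=O)[C@@H]1C` gives 21.4 nM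

Compound 2 holds the lower of the two numbers in this assay and compound 1 lies above it by a margin beyond the scatter. The two differ in more than one place, so their gap does not size any single change.

Compound 3 `COc1ccc(C[C@H]2C(=O)N[C@@H](C)C(=O)N(C)[C@H]3Cc4ccc(cc4)Oc4cc(ccc4OC)C[C@@H](C(=O)N[C@H](C)C(=O)N(C/C=C/c4ccccc4)[C@@H](C)C(=O)N2C)N(C)C3=O)cc1` carries one change from compound 2 (2-phenylethenyl in place of butyl on a saturated chain carbon bound to an amide-type nitrogen in a ring) with 2-phenylethenyl in place of butyl on a saturated chain carbon bound to an amide-type nitrogen in a ring. Going by the values given here, no measured pair covers this change, so the expectation stays anchored on compound 2 at 21.4 nM with a wide range. The expected 2.1-fold higher number from compound 2 to compound 3 (0.32 log units; beyond the scatter) is a modest move toward a higher number, and it may stay within the scatter. For compound 3 the estimated value is 45 nM with an expected range from 12 nM to 200 nM in this assay.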

Compound 3, half-maximal inhibitory concentration: 10.7 nM
For compound 3 the middle estimate is 4.2-fold (0.62 log units) above the measured one; measured number outside the range, below it.
By their numbers in this assay, from the lowest: compounds 3 and 2 (each within the scatter of the next); then compound 1.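

In this assay, 2-phenylethenyl in place of butyl on a saturated chain carbon bound to an amide-type nitrogen in a ring gives a 2.0-fold lower number from compound 2 to compound 3 (0.30 log units; within the scatter) and so leaves the two compounds unseparated. Going by these compounds alone, this position therefore accommodates a group with a six-membered aromatic ring and a double bond outside it, with no loss of cytotoxicity beyond the scatter, which the earlier compounds could not show. No supporting data bear on why the read-out holds across this change.

The compounds shown leave open whether the aromatic ring or the double bond matters, for example whether a saturated 2-phenylethyl group would read the same as 2-phenylethenyl. On these data alone, how this position responds to a chain ending in an amine or a carboxylic acid also remains open.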